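The compounds below may be only part of what the source reports. "The series", "measured", "known", "first", "only" and "open" are said of these compounds alone.

Measured so far in a functional assay on NCI-H1993 cells (Homo sapiens) for inhibition, read by CCK-8 assay, with a stated time of 72 h; a lower number here means a stronger inhibitor, a higher number a weaker inhibitor:
Compound 1 `CC(c1cc(F)c2ncccc2c1)n1cnc2ncc(-c3cn[nH]c3)nc21`: > 10000 nM
Compound 2 `CCC(c1ccc2ncccc2c1F)n1cnc2ncc(-c3cnn(CCO)c3)nc21`: "not determined" (no result reported)
Compound 3 `c1cnc2ccc(Cn3cnc4ncc(-c5cn[nH]c5)nc43)cc2c1`: 2890 nM

Compound 1 gives only a limit, > 10000 nM, and not a number. Compound 4 `CC(c1cc(F)c2ncccc2c1)n1cnc2ncc(-c3cnc4ccccc4c3)nc21` carries quinolin-3-yl in place of 1H-pyrazol-4-yl on an aromatic carbon of the core of compound 1: quinolin-3-yl in place of 1H-pyrazol-4-yl on an aromatic carbon. Within the data shown here, no measured step bears on this exchange. Among the measured compounds shown here, the only number in the set is that of compound 3, 2890 nM, and it sets the scale for the expectation. A modest gain in this assay is expected, and a reading at the limit remains quite possible. The estimated change is an at least 2.0-fold lower number from compound 1 to compound 4 (0.30 log units; that floor lies within the scatter). For compound 4 the expected value is 5000 nM, with an estimated range of 500 nM to 20000 nM.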

Compound 4, half-maximal inhibitory concentration: > 10000 nM
Compound 4: only a limit was reported; the forecaster's own chance of this, stated with the estimate: 45%; at least 2.0-fold (0.30 log units) between middle value and limit.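

No step can be read from compound 1 to compound 4, because both readings are limits and not numbers: the limit of > 10000 nM in this assay, at which 2 of the 4 values shown sit. On these data alone, whether quinolin-3-yl or 1H-pyrazol-4-yl on the shared core gives the lower number stays open.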